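This account rests on a few compounds, and the source may have more. Where it says the series, first, only, none or still open, it means among the compounds named here.

Three compounds were measured in a functional assay on HT-29 cells (Homo sapiens) for antiproliferative activity, read by sulforhodamine B assay, with a stated time of 48 h; a lower number here means a stronger inhibitor, a higher number a weaker inhibitor:

Compound 1, `CC(=O)Nc1ccc(S(=O)(=O)Oc2ccccc2I)cc1`, gives 23000 nM.
Compound 2, `CCC(=O)Nc1ccc(S(=O)(=O)Oc2ccccc2I)cc1`, gives 11000 nM.
Compound 3, `CCNC(=O)Nc1ccc(S(=O)(=O)Oc2ccccc2I)cc1`, gives 5300 nM.

Compound 3 has the lowest number of the three: a 2.1-fold lower number from compound 2 to compound 3 (0.32 log units; beyond the scatter) and a 4.3-fold lower number from compound 1 to compound 3 (0.64 log units; beyond the scatter), both beyond the scatter, so it is the strongest inhibitor among those measured. Compound 4, `O=C(NCC1CCCC1)Nc1ccc(S(=O)(=O)Oc2ccccc2I)cc1`, differs from compound 3 by cyclopentyl in place of methyl on a saturated chain carbon bound to an amide-type nitrogen. Among the compounds with values here, no measured step alters this outer part of the chain, so the guidance is indirect. The closest comparison is a 2.1-fold lower number from compound 1 to compound 2 (0.32 log units; beyond the scatter), where the chain on the carbon bound to the carbonyl carbon grew and the number fell modestly. The change here is larger and sits on the carbon bound to the amide-type nitrogen, so the outcome is uncertain; a modest fall in number, or no change beyond the scatter, is expected rather than a large shift in either direction. Compound 4 is therefore estimated at 3000 nM, with a range of 1200 nM to 8000 nM, which means an expected step of a 1.8-fold lower number from compound 3 to compound 4 (0.25 log units; within the scatter).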

Compound 4, half-maximal inhibitory concentration: 7600 nM
For compound 4 the middle estimate is 2.5-fold (0.40 log units) below the measured one; the range from low to high includes it.
By their numbers in this assay, from the lowest: compounds 3, 4 and 2 (each within the scatter of the next, the first and the last beyond it); then compound 1.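

In this assay, within the data shown here, the step from ethyl to cyclopentylmethyl on the amide-type nitrogen gives a 1.4-fold higher number from compound 3 to compound 4 (0.16 log units; within the scatter) and so stays within the scatter, which shows that this position accepts a five-membered non-aromatic ring of carbon only without a measurable loss, but also without the further fall in number seen in the earlier steps. The (cyclopentylmethyl)amino group in place of ethyl on the carbonyl carbon gives a 1.4-fold lower number from compound 2 to compound 4 (0.16 log units; within the scatter) and also stays within the scatter, while in place of methyl it gives a 3.0-fold lower number from compound 1 to compound 4 (0.48 log units; beyond the scatter) and lies beyond it. No measurement on hand explains this result.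

As far as these compounds go, it remains open whether a longer straight chain or a phenyl ring at this position would separate from compound 3. An amine or a carboxylic acid on the chain is equally untested among the compounds shown.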